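Compound 2 to compound 3: one added methoxy

This account rests on a few compounds, and the source may have more. Where it says the series, first, only, none or still open, it means among the compounds named here.

Of the compounds shown here, two have been measured so far in a functional assay on OVCAR-3 cells (Homo sapiens) for cytotoxicity (on this read-out higher numbers stand for weaker inhibition of growth and lower numbers for stronger inhibition of growth), and neither has a number. Compound 1 (`COc1ccc(C23OCC24C(CO)C4Cc2cc(OC)c(OC)cc23)cc1OC`) gives > 100000 nM as a limit of the assay. Compound 2 (`COc1ccc(C23OCC24C2COC(c5cc(OC)c(OC)cc53)C24)cc1OC`) gives > 100000 nM which is likewise a limit and not a number. The position of compound 2 is thus described only by the limit of > 100000 nM in this assay, at which 2 of the 2 values shown sit, and by nothing finer. Compound 3 (`COc1cc2c(cc1OC)C1(c3cc(OC)c(OC)c(OC)c3)OCC13C1COC2C13`) has methoxy in place of hydrogen on an aromatic carbon of compound 2. Among the compounds with values here, no measured step for this change is available in this assay so the expectation rests on the limit of > 100000 nM in this assay, at which 2 of the 2 values shown sit, alone. No shift in either direction beyond the scatter is expected, and the estimated step of a number no higher from compound 2 to compound 3 (the limit leaves the size open) is small. For compound 3 the estimated value is 100000 nM with an expected range from 30000 nM to 300000 nM in this read-out.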

Compound 3, concentration for 50% growth inhibition: 30200 nM
Compound 3: middle estimate off by 3.3-fold (0.52 log units), on the high side; the measured number falls inside the stated range.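

In this assay, methoxy in place of hydrogen on this aromatic carbon, ortho to a methoxy group and meta to a large group, gives an at least 3.3-fold lower number from compound 2 to compound 3 (0.51 log units; beyond the scatter). This position therefore responds to substitution, and compound 3 is the only compound shown with a number rather than a limit. The true size of the step stays open, because compound 2 gives only a limit of the assay: the limit of > 100000 nM in this assay, at which 2 of the 3 values shown sit.

The compounds shown leave open whether hydroxy, fluorine or an amine at this carbon would lower the number as methoxy does. Also open, going by these compounds, is whether the same change on the core of compound 1 would bring it off its limit.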